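Working notes on chain lengthening from compound 3 to compound 4

The source may hold more compounds than are shown below. What is called first, only, known or untested is meant among the compounds shown, and "the series" means these compounds.

Measured so far:
- compound 1, `CCN(CC)c1nc(C)c2[nH]c(SCC(=O)NCCN)nc2n1`; in an ADME assay on CEM174 cells (Homo sapiens) for cytotoxicity (a higher number here means that more compound is tolerated, a lower number that less compound is tolerated), compound 1 gives > 100 uM, a limit of the assay.
- compound 2, `CCN(CC)c1nc(C)c2[nH]c(SCC(=O)NCCCN)nc2n1`; in this assay compound 2 gives > 100 uM, again a limit.
- compound 3, `CCN(CC)CC[n+]1c(SCC(=O)NCCN)[nH]c2c(C)nc(N(CC)CC)nc21`; in this assay compound 3 gives 52.2 uM.

For the measured compounds named here, compound 3 thus stands as the only number in this assay; the two other values are limits, as summed up by the limit of > 100 uM in this assay, at which 2 of the 3 values shown sit.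

Compound 4, `CCN(CC)CC[n+]1c(SCC(=O)NCCCN)[nH]c2c(C)nc(N(CC)CC)nc21`, is not yet measured. It differs from compound 3 by aminomethyl in place of amino on a saturated chain carbon, two bonds along the chain from an amide-type nitrogen.

Going by the values given here, the one measured step of the same kind, a step that the two limits leave unreadable from compound 1 to compound 2, cannot be read, since both ends sit at a limit. Among the compounds with values here, there is therefore no measured step that tells the direction or size of the change in this assay, and the expectation rests on the change alone.

In the absence of a readable precedent, no step beyond the usual scatter is expected from compound 3 to compound 4, so the step is estimated as a 1.1-fold higher number from compound 3 to compound 4 (0.02 log units; within the scatter). For compound 4 the value in this assay is accordingly expected near 55 uM, within a range of 25 uM to 110 uM.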

Compound 4, half-maximal toxic concentration: > 100 uM
Compound 4: only a limit was reported; the forecaster's own chance of this, stated with the estimate: 20%; middle value at least 1.8-fold (0.25 log units) from the limit.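

Compound 4 gives > 100 uM in this assay, which is a limit of the assay. For the compounds shown here, this makes compound 3 and compound 4 the first pair in which amino to aminomethyl, on a saturated chain carbon, two bonds along the chain from an amide-type nitrogen, can be given a bound: an at least 1.9-fold higher number from compound 3 to compound 4 (0.28 log units; that floor lies within the scatter). The same change from compound 1 to compound 2 cannot be read, since both ends sit at a limit, whereas the pair here starts from a number and shows no loss of tolerance with the longer chain, although its floor alone does not establish a change beyond the scatter.

From the compounds shown here alone, the true size of the step stays open because the reading stops at the same limit as the other compounds: the limit of > 100 uM in this assay, at which 3 of the 4 values shown sit. Also open is whether a longer chain such as 4-aminobutyl, or a carboxylic acid or hydroxyl group in place of the amine, would give a number or the same limit in this assay.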